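Cyano in place of fluoro on the sulfonyl group

The compounds below may be only part of what the source reports. "The series", "measured", "known", "first", "only" and "open" are said of these compounds alone.

Working notes on the series. The compounds are compared in a functional assay on HCT-116 cells (Homo sapiens) for inhibition; a lower number here means a stronger inhibitor, a higher number a weaker inhibitor. Compound 1 `CN1CCN(c2ccc(C3=NN(C(=O)c4ccc(C(F)(F)F)cc4)C(c4ccc(N(C)C)cc4)C3)cc2)CC1` gives > 10000 nM, which is a limit of the assay rather than a number. Compound 2 `CN1CCN(c2ccc(C3=NN(C(=O)/C=C/c4ccccc4)C(c4ccc(N(C)C)cc4)C3)cc2)CC1` likewise gives > 10000 nM, again a limit. Compound 3 `CN1CCN(c2ccc(C3=NN(S(=O)(=O)c4ccc(F)cc4)C(c4ccc(N(C)C)cc4)C3)cc2)CC1` stands at > 10000 nM, also a limit, so its place on the numbers shown is at the limit together with the other two, and no ordering among the three is readable. The steps a step that the two limits leave unreadable from compound 1 to compound 2, a step that the two limits leave unreadable from compound 1 to compound 3 and a step that the two limits leave unreadable from compound 2 to compound 3 are accordingly of no readable size; what they share is the limit of > 10000 nM in this assay, at which 3 of the 3 values shown sit.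

Compound 4 `CN1CCN(c2ccc(C3=NN(S(=O)(=O)c4ccc(C#N)cc4)C(c4ccc(N(C)C)cc4)C3)cc2)CC1` is not yet measured. It differs from compound 3 in one place: cyano in place of fluoro on an aromatic carbon. Among the compounds with values here, none of the measured steps touches this part of the structure; the measured steps vary the group on the amine nitrogen in a ring and leave no readable size, so they give no direction for the change in compound 4. With every measured value sitting at the limit, the step expected for compound 4 in this assay is a step that the limit leaves unreadable from compound 3 to compound 4, most likely remaining at the limit. The estimate for compound 4 is 15000 nM with a range from 3000 nM to 50000 nM.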

Compound 4, half-maximal inhibitory concentration: 3600 nM
Compound 4: the middle estimate sits 4.2-fold (0.62 log units) above what was measured; the measured number falls inside the stated range.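

Within the data shown here, on the aromatic carbon para to the large group, a position that no earlier step touched, cyano in place of fluoro brings the first reading off the limit in this assay (an at least 2.7-fold lower number from compound 3 to compound 4 (0.44 log units; beyond the scatter)) and so shows that this position of the (4-fluorophenyl)sulfonyl group can move the number. With the (4-cyanophenyl)sulfonyl group on the amine nitrogen in a ring, the comparisons with the two carbonyl compounds also become readable (an at least 2.7-fold lower number from compound 2 to compound 4 (0.44 log units; beyond the scatter) and an at least 2.7-fold lower number from compound 1 to compound 4 (0.44 log units; beyond the scatter)) and stay beyond the scatter. All three sizes are only lower bounds and the steps among compound 1, compound 2 and compound 3 cannot be read, because those three compounds sit at a limit: the limit of > 10000 nM in this assay, at which 3 of the 4 values shown sit.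

The compounds shown leave open how large the step from fluoro to cyano really is, and whether another group at this place, such as an amine, a carboxylic acid or a methoxy group, would give a lower or a higher number than compound 4. They also leave open whether cyano on the aromatic ring of a carbonyl compound would bring a similar step.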